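The source may hold more compounds than are shown below. What is called first, only, known or untested is meant among the compounds shown, and "the series" means these compounds.

Measured so far:
compound 1 `COc1ccc(/C=C/C(=O)c2c(C)cc(O)c(C(=O)/C=C/c3ccc(OC)cc3)c2-c2ccccc2)cc1`: "not active" (no number reported)
compound 2 `Cc1cc(O)c(C(=O)/C=C/c2ccc3ccccc3c2)c(-c2ccccc2)c1C(=O)/C=C/c1ccc2ccccc2c1`: 30000 nM

In a functional assay on MDA-MB-231 cells (Homo sapiens) for cytotoxicity, read by MTT assay, with a stated time of 24 h (a lower number here means a stronger inhibitor, a higher number a weaker inhibitor), compound 1 shows "not active" (no number reported), so there is no single number to place it on. Among the compounds with values here, compound 2, the only compound with a number, gives 30000 nM in this assay. Within the data shown here, no step between these two is on record; they differ in more than one place.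

Compound 3 `COc1ccc(/C=C/C(=O)c2c(C)cc(O)c(C(=O)/C=C/c3ccc(OC)cc3)c2-c2ccc(Br)cc2)cc1` differs from compound 1 in one place: bromo in place of hydrogen on an aromatic carbon. Among the measured compounds shown here, with compound 1 lacking a number, no direction for this step in this assay can be anchored; a change no larger than the usual scatter is expected, with a real chance that again no number results. Compound 3 is expected at 40000 nM, within 15000 nM to 110000 nM.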

Compound 3, half-maximal inhibitory concentration: "not active" (no number reported)
For compound 3 the study gives words and no number, and the estimate cannot be compared.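

No step can be read between compound 1 and compound 3, as neither carries a number. No evidence on hand bears on this result. Going by these compounds, whether phenyl to 4-bromophenyl changes the read-out in this assay on a compound with a measurable value stays open.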